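A few compounds are considered here, and "the series" means these few. Any claim that something is new, unique, unknown or untested is made for them only; others in the source may bear on it.

Series notes. Compound 1 `O=C(Nc1cccc(-c2oc3cc(-c4ccc(F)cc4)ccc3c(=O)c2O)c1)c1ccc(F)cc1` gives 6930 nM in a functional assay on A549 cells (Homo sapiens) for antiproliferative activity, read by CCK-8 assay, with a stated time of 72 h; on this read-out higher numbers stand for weaker inhibition and lower numbers for stronger inhibition. Compound 2 `O=C(Nc1cccc(-c2oc3cc(-c4ccc(F)cc4)ccc3c(=O)c2O)c1)c1ccc(Cl)cc1` gives 10800 nM in this assay, and a 1.6-fold higher number from compound 1 to compound 2 (0.19 log units; within the scatter). Compound 3 `O=C(Nc1cccc(-c2oc3cc(-c4ccc(F)cc4)ccc3c(=O)c2O)c1)c1ccc(Br)cc1F` gives 46100 nM in this assay, the highest of the three numbers: a 6.7-fold higher number from compound 1 to compound 3 (0.82 log units; beyond the scatter), and a 4.3-fold higher number from compound 2 to compound 3 (0.63 log units; beyond the scatter). Compound 4 `COc1ccc(C(=O)Nc2cccc(-c3oc4cc(-c5ccc(F)cc5)ccc4c(=O)c3O)c2)c(F)c1` carries methoxy in place of bromo on an aromatic carbon. Among the compounds with values here, no measured step swaps a halogen for a methoxy on this ring; the two steps reaching compound 3 both raised the number modestly, but each also brought in the fluoro group that compound 4 keeps, so they bear only loosely on the present change. A partial return toward the lower numbers of compound 1 and compound 2 is expected, the estimated step being a 1.8-fold lower number from compound 3 to compound 4 (0.27 log units; within the scatter). Compound 4 is estimated at 25000 nM in this assay, with a range from 8000 nM to 70000 nM.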

Compound 4, half-maximal inhibitory concentration: 40000 nM
Compound 4: middle estimate off by 1.6-fold (0.20 log units), on the low side; low and high end bracket the measured number.
By their numbers in this assay, from the lowest: compounds 1 and 2 (each within the scatter of the next); then compounds 4 and 3 (each within the scatter of the next).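

In this assay, with the fluoro group kept, methoxy and bromo at this position cannot be told apart: a 1.2-fold lower number from compound 3 to compound 4 (0.06 log units; within the scatter). The 2-fluoro-4-methoxyphenyl group still leaves the number well separated from those with the 4-chlorophenyl and 4-fluorophenyl groups, with a 3.7-fold higher number from compound 2 to compound 4 (0.57 log units; beyond the scatter) and a 5.8-fold higher number from compound 1 to compound 4 (0.76 log units; beyond the scatter). Nothing at hand explains these numbers.

Open, on these data alone, is whether the higher numbers follow the fluoro group or the group at this position, which 4-methoxyphenyl on the carbonyl carbon would separate. Also open, as far as these compounds go, is how an amine or a carboxylic acid would read here.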